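Methylpiperidinyl Replacing Pyridinyl on the Ring Nitrogen

This account rests on a few compounds, and the source may have more. Where it says the series, first, only, none or still open, it means among the compounds named here.

Compound 1 `CN1CCC(N2CCN(C(=O)[C@@H]3CCCN3C(=O)c3nc4ccccc4n3Cc3ccccc3)CC2)CC1` gives 884 nM in a functional assay on CHO cells for antagonist activity at B1 bradykinin receptor (Macaca fascicularis), read by FLIPR and calcium flux; on this read-out higher numbers stand for weaker inhibition and lower numbers for stronger inhibition. Compound 2 `CCN(CC(=O)N1CCN(c2ccncc2)CC1)Cc1nc2ccccc2n1Cc1ccccc1` is known only as an assay limit, > 5000 nM, in this assay; at that limit (the limit of > 5000 nM in this assay, at which 1 of the 2 values shown sits). Compound 3 `CCN(CC(=O)N1CCN(C2CCN(C)CC2)CC1)Cc1nc2ccccc2n1Cc1ccccc1` differs from compound 2 by 1-methylpiperidin-4-yl in place of pyridin-4-yl on an amine nitrogen in a ring. Compound 1 carries the same 1-methylpiperidin-4-yl group on a ring nitrogen and gives a number rather than a limit, so a step toward stronger inhibition, beyond the scatter, is expected an at least 2.0-fold lower number from compound 2 to compound 3 (0.30 log units; that floor lies within the scatter). Compound 3 is therefore estimated at 2500 nM, from 600 nM to 8000 nM.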

Compound 3, half-maximal inhibitory concentration: > 5000 nM
Compound 3 ended at the assay's limit (the forecaster's own chance of this, stated with the estimate: 35%); middle value at least 2.0-fold (0.30 log units) from the limit.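

In this assay, within the data shown here, compound 2 and compound 3 both end at a limit, so no step between them can be read. The compounds shown leave open whether 1-methylpiperidin-4-yl in place of pyridin-4-yl changes inhibition at all, and by how much.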